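Swapping the amide ring on the shared core

The compounds below may be only part of what the source reports. "The series", "measured", "known", "first", "only" and "open" are said of these compounds alone.

In a functional assay on A20 cells (Mus musculus) for inhibition, with stated times of 1 h, 16 h and 24 h (a higher number here means a weaker inhibitor, a lower number a stronger inhibitor), compound 1 (`N#CC1(NC(=O)[C@@H]2C[C@@H](S(=O)(=O)c3ccccc3)C[C@H]2C(=O)N2CCOCC2)CC1`) gives 12 nM. Going by the values given here, compound 2 (`C[C@@H]1CN(C(=O)[C@@H]2C[C@H](S(=O)(=O)c3ccccc3)C[C@H]2C(=O)NC2(C#N)CC2)C[C@H](C)O1`) gives 1 nM, the lowest of the two numbers so far. Compound 3 (`N#CC1(NC(=O)[C@@H]2C[C@@H](S(=O)(=O)c3ccccc3)C[C@H]2C(=O)N2CC3CCC(C2)O3)CC1`) differs from it by a group of 8 heavy atoms (6 carbon, 1 nitrogen, 1 oxygen; one five-membered non-aromatic ring with 1 hetero atom, one six-membered non-aromatic ring with 2 hetero atoms) in place of a group of 8 heavy atoms (6 carbon, 1 nitrogen, 1 oxygen; one six-membered non-aromatic ring with 2 hetero atoms), on a carbonyl carbon. Among the compounds with values here, one measured step bears on this change, at the same carbonyl carbon: a 12-fold lower number from compound 1 to compound 2 (1.08 log units; beyond the scatter), large and beyond the scatter, with 2,6-dimethylmorpholin-4-yl in place of morpholin-4-yl. Within the data shown here, no measurement yet covers the entering group, so a small move to a higher number is expected, staying closer to compound 2 than to compound 1. The expected step is a 3.0-fold higher number from compound 2 to compound 3 (0.48 log units; beyond the scatter). For compound 3 the estimated value is 3 nM, with an expected range of 0.8 nM to 12 nM.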

Compound 3, half-maximal inhibitory concentration: 16 nM
Beside the measured number, compound 3's estimate is 5.3-fold (0.73 log units) below it, outside the stated range (above it).
By their numbers in this assay, from the lowest: compound 2; then compounds 1 and 3 (each within the scatter of the next).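

In this assay, the group with one five-membered and one six-membered non-aromatic ring does not keep the result seen with 2,6-dimethylmorpholin-4-yl, with a 16-fold higher number from compound 2 to compound 3 (1.20 log units; beyond the scatter) at this carbonyl carbon. Against morpholin-4-yl, the step is a 1.3-fold higher number from compound 1 to compound 3 (0.12 log units; within the scatter), which is within the scatter, so 8 heavy atoms at this position do not alone set the number. No evidence on hand accounts for this difference. Still open, as far as these compounds go, is how a single methyl on the morpholine ring would compare, and whether piperidin-1-yl would hold the number without the ring oxygen.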